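1,3-Thiazol-2-yl for pyrimidin-2-yl on a sulfonamide nitrogen

The source may hold more compounds than are shown below. What is called first, only, known or untested is meant among the compounds shown, and "the series" means these compounds.

Compound 1 `O=C1/C(=C/c2coc3ccccc3c2=O)N=C(c2ccc(Cl)cc2)N1c1ccc(S(=O)(=O)Nc2ncccn2)cc1` gives in a functional assay on MCF7 cells (Homo sapiens) for cytotoxicity, read by sulforhodamine B assay, with a stated time of 72 h (a lower number here means a stronger inhibitor, a higher number a weaker inhibitor), only a limit of the assay, > 100000 nM. Compound 2 `O=C1/C(=C/c2coc3ccccc3c2=O)N=C(c2ccc(Cl)cc2)N1c1ccc(S(=O)(=O)Nc2nccs2)cc1`, which carries 1,3-thiazol-2-yl in place of pyrimidin-2-yl on a sulfonamide nitrogen, likewise gives in this assay only a limit, > 100000 nM. The step that the two limits leave unreadable from compound 1 to compound 2 therefore cannot be read. Compound 3 `O=c1c(CNc2ccc(S(=O)(=O)Nc3ncccn3)cc2)coc2ccccc12` differs from compound 1 in its core, and that difference is not broken down here. In this assay compound 3 also gives only a limit, > 100000 nM. Compound 4 `O=c1c(CNc2ccc(S(=O)(=O)Nc3nccs3)cc2)coc2ccccc12` carries 1,3-thiazol-2-yl in place of pyrimidin-2-yl on a sulfonamide nitrogen, the same change as from compound 1 to compound 2, at a place described in the same words. Going by the values given here, because of the limit of > 100000 nM in this assay, at which 3 of the 3 values shown sit, no measured step has a readable size to lean on. Compound 4 is therefore expected to sit at the limit as well, with an estimate of 100000 nM and a range from 40000 nM to 300000 nM. The step of a number no higher from compound 3 to compound 4 (the limit leaves the size open) is expected to be essentially flat.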

Compound 4, half-maximal inhibitory concentration: 58600 nM
Compound 4: middle estimate off by 1.7-fold (0.23 log units), on the high side; the measured number falls inside the stated range.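

In this assay, going by these compounds alone, 1,3-thiazol-2-yl in place of pyrimidin-2-yl on a sulfonamide nitrogen gives an at least 1.7-fold lower number from compound 3 to compound 4 (0.23 log units; that floor lies within the scatter), the only size this change has. On the core of compound 1 the same change cannot be read, both values there being limits, so the data show neither that the step carries from one core to the other nor that it differs between them. The step is a floor within the scatter, and the series offers little else to read: the limit of > 100000 nM in this assay, at which 3 of the 4 values shown sit.

Left open is whether a pyridin-2-yl ring or an acetyl group on the sulfonamide nitrogen would give a readable number on either core. Also open, from the compounds shown here alone, is what a carboxylic acid or a longer chain would do on the core of compound 3.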